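The compounds below may be only part of what the source reports. "The series", "measured", "known", "first", "only" and "open" are said of these compounds alone.

Of the compounds shown here, three have so far been measured in an ADME assay on MT4 cells (Homo sapiens) for cytotoxicity, read by MTT assay, with a stated time of 96 h; on this read-out higher numbers stand for lower toxicity in this test and lower numbers for higher toxicity in this test. Compound 1 `O=C(CN1CCCCC1)Nc1ccc(-c2nc3cc(C(F)(F)F)ccc3[nH]2)cc1` gives 6000 nM, compound 2 `COc1ccc(-c2nc3cc(Cl)c(Cl)cc3[nH]2)c(N)c1` gives 3000 nM, and compound 3 `CCN(CC)CC(=O)Nc1ccc(-c2nc3cc(C(F)(F)F)ccc3n2C)cc1` gives 9000 nM. On these numbers compound 3 stands highest, but its gap to compound 1 lies within the scatter, so the two cannot be told apart; only compound 2 sits clearly lower, beyond the scatter.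

The piece now turns to compound 4 `CN1CCN(CC(=O)Nc2ccc(-c3nc4cc(C(F)(F)F)ccc4n3C)cc2)CC1`, which has not yet been measured in this assay. It differs from compound 3 in one place: 4-methylpiperazin-1-yl in place of diethylamino on a saturated chain carbon bound to a carbonyl carbon. Going by the values given here, no measured pair among the three compounds shares this exchange of diethylamino for 4-methylpiperazin-1-yl, so nothing in the data says what size of step it brings. Because compound 3 already gives 9000 nM, the step of a 1.1-fold higher number from compound 3 to compound 4 (0.05 log units; within the scatter) is expected to stay within the scatter, with no clear direction. Compound 4 is therefore estimated at 10000 nM, with a range from 4000 nM to 25000 nM.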

Compound 4, half-maximal cytotoxic concentration: 22000 nM
For compound 4 the middle estimate is 2.2-fold (0.34 log units) below the measured one; low and high end bracket the measured number.
By their numbers in this assay, from the lowest: compounds 2, 1 and 3 (each within the scatter of the next, the first and the last beyond it); then compound 4.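

In this assay, going by these compounds alone, 4-methylpiperazin-1-yl in place of diethylamino gives a 2.4-fold higher number from compound 3 to compound 4 (0.39 log units; beyond the scatter), the first step between two compounds that differ in one place. It shows that the group on this saturated chain carbon bound to a carbonyl carbon can shift the read-out beyond the scatter, here modestly and towards lower toxicity in this test. Nothing in the available data accounts for this shift.

This is a single pair, so it cannot show whether the same exchange would have a similar effect on the core of compound 1. It also leaves open how a morpholin-4-yl group, or a piperazin-1-yl group without the methyl, would read at this place, and so whether the methyl or the ring itself goes with the step.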